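Cycloheptyl in place of cyclopropylmethyl on the ring nitrogen

This account rests on a few compounds, and the source may have more. Where it says the series, first, only, none or still open, it means among the compounds named here.

Three compounds share one core and differ only in the group on the aromatic nitrogen. In an assay on isolated protein for agonist activity at Bile acid receptor (Homo sapiens), read by TR-FRET (on this read-out lower numbers stand for an effect already at smaller amounts and higher numbers for an effect only at larger amounts of compound), compound 1 `CCCn1c(-c2ccc(OCc3c(-c4c(Cl)cccc4Cl)noc3C(C)C)cc2)nc2ccc(C(=O)O)cc21` gives 96.4 nM, compound 2 `CC(C)c1onc(-c2c(Cl)cccc2Cl)c1COc1ccc(-c2nc3ccc(C(=O)O)cc3n2C2CC2)cc1` gives 117 nM, and compound 3 `CC(C)c1onc(-c2c(Cl)cccc2Cl)c1COc1ccc(-c2nc3ccc(C(=O)O)cc3n2CC2CC2)cc1` gives 29.1 nM. Compound 3 stands lowest of the three: the step of a 3.3-fold lower number from compound 1 to compound 3 (0.52 log units; beyond the scatter) and the step of a 4.0-fold lower number from compound 2 to compound 3 (0.60 log units; beyond the scatter) both lie beyond the scatter, while the step of a 1.2-fold higher number from compound 1 to compound 2 (0.08 log units; within the scatter) does not.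

Compound 4 `CC(C)c1onc(-c2c(Cl)cccc2Cl)c1COc1ccc(-c2nc3ccc(C(=O)O)cc3n2C2CCCCCC2)cc1` carries the change (cycloheptyl in place of cyclopropylmethyl on an aromatic nitrogen). The measured steps that bear on it are those that exchange one group for another at this nitrogen: the exchange from propyl to cyclopropyl left the number unchanged within the scatter, and the exchange from cyclopropyl to cyclopropylmethyl lowered it modestly. None of them involves a seven-membered ring, so the direction of the new step rests on thin ground. The author therefore expects for compound 4 in this assay a step of a 2.4-fold higher number from compound 3 to compound 4 (0.38 log units; beyond the scatter), most likely a modest rise in the number, with a wide range. The estimate for compound 4 is 70 nM, between 20 nM and 250 nM.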

Compound 4, half-maximal effective concentration: 113 nM
The estimate for compound 4 lay 1.6-fold (0.21 log units) below the measured number, within the range that was stated.
By their numbers in this assay, from the lowest: compound 3; then compounds 1, 4 and 2 (each within the scatter of the next).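

At the aromatic nitrogen in this assay, cycloheptyl in place of cyclopropylmethyl gives a 3.9-fold higher number from compound 3 to compound 4 (0.59 log units; beyond the scatter), so the low number of compound 3 does not carry over to this seven-membered ring. Set against the other two groups, the same ring gives a 1.0-fold lower number from compound 2 to compound 4 (0.02 log units; within the scatter) for cyclopropyl and a 1.2-fold higher number from compound 1 to compound 4 (0.07 log units; within the scatter) for propyl, so a three-membered ring, a seven-membered ring and an open chain cannot be told apart at this nitrogen, and among the four compounds only the cyclopropylmethyl of compound 3 stands apart from the rest. The data shown offer no explanation for why cyclopropylmethyl alone stands apart.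

The compounds shown leave open whether the low number belongs to cyclopropylmethyl alone or also appears with close relatives such as cyclobutylmethyl or an isobutyl chain, and whether cyclopentyl or cyclohexyl would behave like cycloheptyl. They also leave open what a hydroxyl group or an amine on the group at this nitrogen would do to the number in this assay.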